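The source may hold more compounds than are shown below. What is called first, only, known or untested is meant among the compounds shown, and "the series" means these compounds.

Compound 3 `O=S(=O)(NCCCNCc1cccc2ccccc12)c1cc(C(F)(F)F)cc(C(F)(F)F)c1` stands lowest of the three numbers in a functional assay on MCF7 cells (Homo sapiens) for inhibition, read by MTT assay, with a stated time of 72 h (on this read-out higher numbers stand for weaker inhibition of growth and lower numbers for stronger inhibition of growth), where compound 3 gives 1400 nM. Compound 2 `O=S(=O)(NCCCNCc1ccccc1)c1cc(C(F)(F)F)cc(C(F)(F)F)c1` gives 3000 nM, and compound 1 `CN(CCCNS(=O)(=O)c1cc(C(F)(F)F)cc(C(F)(F)F)c1)Cc1ccccc1` gives 16000 nM; the two steps are a 5.3-fold lower number from compound 1 to compound 2 (0.73 log units; beyond the scatter) and a 2.1-fold lower number from compound 2 to compound 3 (0.33 log units; beyond the scatter). Compound 4 `COc1ccccc1CNCCCNS(=O)(=O)c1cc(C(F)(F)F)cc(C(F)(F)F)c1` differs from compound 3 by 2-methoxyphenyl in place of naphthalen-1-yl on a saturated chain carbon bound to an amine nitrogen. Among the measured compounds shown here, the only step that bears on this change is a 2.1-fold lower number from compound 2 to compound 3 (0.33 log units; beyond the scatter), which shows what the larger aromatic group brought over phenyl; the incoming group lies between the two in what it carries, so a modest rise in the number is expected, a 1.6-fold higher number from compound 3 to compound 4 (0.20 log units; within the scatter). Compound 4 is therefore estimated at 2200 nM in this assay, with a range of 900 nM to 5500 nM.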

Compound 4, concentration for 50% growth inhibition: 2600 nM
For compound 4 the middle estimate is 1.2-fold (0.07 log units) below the measured one, within the range that was stated.
By their numbers in this assay, from the lowest: compounds 3, 4 and 2 (each within the scatter of the next, the first and the last beyond it); then compound 1.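

In this assay 2-methoxyphenyl and naphthalen-1-yl on this saturated chain carbon cannot be told apart, with a 1.9-fold higher number from compound 3 to compound 4 (0.27 log units; within the scatter) as the step. Methoxy in place of hydrogen on the aromatic carbon is equally unresolved, with a 1.2-fold lower number from compound 2 to compound 4 (0.06 log units; within the scatter) as the step. Only a 6.2-fold lower number from compound 1 to compound 4 (0.79 log units; beyond the scatter) lies beyond the scatter, and that step combines the methoxy with the change at the amine nitrogen, while no measurement on hand accounts for these numbers.

As far as these compounds go, whether pyridin-3-yl in place of 2-methoxyphenyl, or a longer chain linking the two nitrogens, would shift the number stays open.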